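This account rests on a few compounds, and the source may have more. Where it says the series, first, only, none or still open, it means among the compounds named here.

Series notes, cytotoxicity arm. The read-out is an ADME assay on BCBL1 cells (Homo sapiens) for cytotoxicity, with a stated time of 7 days; on this read-out higher numbers stand for lower toxicity in this test and lower numbers for higher toxicity in this test. Three compounds have been run. Compound 1 is `CCCOc1nc(N)nc2c1ncn2/C=C1/CC1(CO)CO`; compound 2 is `CCCSc1nc(N)nc2c1ncn2/C=C1/CC1(CO)CO`; compound 3 is `CCCCCCSc1nc(N)nc2c1ncn2/C=C1/CC1(CO)CO`. They share one core and differ only in the group on the aromatic carbon.

In this assay compound 1 gives > 20000 nM, which is a limit of the assay and not a number. Compound 2 likewise returns a limit, > 20000 nM. Compound 3 also returns a limit, > 20000 nM.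

Because all three sit at the limit of > 20000 nM in this assay, at which 3 of the 3 values shown sit, none of the steps can be read: a step that the two limits leave unreadable from compound 1 to compound 2, a step that the two limits leave unreadable from compound 1 to compound 3, and a step that the two limits leave unreadable from compound 2 to compound 3. Compound 3 therefore stands on a limit only, and the two other values in the set are limits as well.

Next in line is compound 4, `CN(C)c1nc(N)nc2c1ncn2/C=C1/CC1(CO)CO`. It differs from compound 3 by dimethylamino in place of hexylsulfanyl on an aromatic carbon.

Among the compounds with values here, no measured step bears readable size on this change; the only evidence is that every compound so far sits at the limit of > 20000 nM in this assay, at which 3 of the 3 values shown sit. The expectation for this assay is therefore no change beyond the scatter, expressed as a step that the limit leaves unreadable from compound 3 to compound 4, with a high chance of another limit. Compound 4 is expected at 25000 nM, within 12000 nM to 60000 nM.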

Compound 4, half-maximal cytotoxic concentration: > 20000 nM
Compound 4 was reported as a limit; the forecaster's own chance of this, stated with the estimate: 80%; the middle value is on the limit's open side.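

In this assay compound 4 gives > 20000 nM, a limit of the assay and not a number. No step among compound 1, compound 2, compound 3 and compound 4 can be read: the limit of > 20000 nM in this assay, at which 4 of the 4 values shown sit.

Still open, from the compounds shown here alone, is whether any group on the aromatic carbon of the shared core gives a readable value in this assay.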